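The compounds below may be only part of what the source reports. "The series", "measured", "known", "first", "only" and "open" are said of these compounds alone.

Compound 1 `Cc1cn(C2CCN(Cc3cccc(Oc4cc(F)cc(F)c4)c3)CC2)c(=O)[nH]c1=O` gives > 64000 nM in an ADME assay on MRC5 cells (Homo sapiens) for cytotoxicity, read by fluorescence and resazurin assay, with a stated time of 3 days; on this read-out higher numbers stand for weaker inhibition and lower numbers for stronger inhibition. Compound 2 `Cc1cn(C2CCN(Cc3cccc(Oc4ccc(O)cc4)n3)CC2)c(=O)[nH]c1=O` gives "not determined" (no result reported) in this assay. Compound 3 `Cc1cn(C2CCN(Cc3ccnc(Oc4cccc(Cl)c4)c3)CC2)c(=O)[nH]c1=O` gives > 64000 nM in this assay.

The value shown for compound 1 is a limit of this assay and not a number. Compound 1 therefore stands at the limit of > 64000 nM in this assay, at which 2 of the 3 values shown sit, and the value shown for compound 3 is a limit as well, so the two read-outs that carry any figure sit together at the same edge. For compound 2 no result is reported. No pair of these compounds differs in a single place, so no measured step is available to compare with.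

Compound 4 `Cc1cn(C2CCN(Cc3cccc(Oc4cc(Cl)cc(Cl)c4)c3)CC2)c(=O)[nH]c1=O` differs from compound 1 in one place: 3,5-dichlorophenyl in place of 3,5-difluorophenyl on an oxygen on an aromatic ring. Among the compounds with values here, with no measured step to lean on, the step from compound 1 to compound 4 is expected to be small, most likely none beyond the scatter, and if anything toward slightly stronger inhibition; in this assay the expected step is an at least 1.1-fold lower number from compound 1 to compound 4 (0.06 log units; that floor lies within the scatter). Compound 4 is accordingly estimated at 55000 nM, within a range from 15000 nM to 200000 nM, with a fair chance that this assay again returns only a limit for compound 4.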

Compound 4, half-maximal inhibitory concentration: 6730 nM
Compound 4: the middle estimate sits 8.2-fold (0.91 log units) above what was measured; the measured number lies below the stated range.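

Within the data shown here, with 3,5-dichlorophenyl in place of 3,5-difluorophenyl on an oxygen on an aromatic ring, the read-out moves by an at least 9.5-fold lower number from compound 1 to compound 4 (0.97 log units; beyond the scatter) in this assay, so this position is sensitive to the change, which the earlier compounds could not show. Among these compounds, compound 4 is also the first compound here to give a true number rather than a limit, which means that cytotoxicity can be measured within this set of compounds. Against that number, the other figures shown remain at the edge of the assay: the limit of > 64000 nM in this assay, at which 2 of the 4 values shown sit.

Going by these compounds, the full size of the step remains open, since the value for compound 1 is a limit and not a number. Also open, on these data alone, is what 3,5-dibromophenyl or 3,5-dimethylphenyl on the same oxygen would give, and whether a single chlorine on that ring would suffice.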